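One More Hydroxy Group on the Ring of Compound 2

The source may report more compounds than this note shows. Statements on the series, on what has been measured and on what is new or still open speak of the compounds shown alone.

Compound 1 `Cc1ccc(/C=C2\CCC/C(=C\c3ccccc3)C2=O)cc1` gives 34.1% in an assay on isolated protein for inhibition of Alpha glucosidase (Homo sapiens), with stated times of 5 min and 15 min, tested at 50 uM; a lower number here means less inhibition, a higher number more inhibition at the concentration tested (going by the name of the read-out).
Compound 2 `O=C(/C=C(O)/C=C/c1cccc(O)c1)c1cc(Cl)ccc1O` gives 62.4% in this assay.
Compound 3 `O=C(/C=C(O)/C=C/c1cc(O)ccc1O)c1cc(O)ccc1O` gives 96.9% in this assay.

Among these three numbers, compound 2 stands second highest. Compound 1 lies below it by a gap beyond the usual scatter, and compound 3 lies above it by a gap that is also beyond the scatter. Going by the values given here, no pair among the three differs in only one place, so these values show order but no single-change step.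

Compound 4 `O=C(/C=C(O)/C=C/c1ccc(O)c(O)c1)c1cc(Cl)ccc1O` has not yet been measured in this assay. It is built from compound 2 by one change: hydroxy in place of hydrogen on an aromatic carbon. Among the compounds with values here, the one comparison that points in a direction is that compound 3 carries hydroxy groups where compound 2 carries hydrogen or chlorine. In this assay compound 3 gives 96.9%, while compound 2 gives 62.4%. Within the data shown here, on that basis a step upward beyond the scatter is expected, though smaller than the whole gap to compound 3, since only one group is added.

Compound 4 is therefore estimated at 78% in this assay, with a range from 62% to 92%. The expected step is a number 15.6 percentage points higher from compound 2 to compound 4 (beyond the scatter).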

Compound 4, a percentage reported as inhibition, at one concentration (the size of the read-out at that concentration, not a potency): 85.6%
Compound 4: the middle estimate sits 7.6 percentage points below what was measured; measured number inside the range.
By their numbers in this assay, from the lowest: compound 1; then compound 2; then compound 4; then compound 3.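

In this assay, swapping one hydrogen for a hydroxy group gives a number 23.2 percentage points higher from compound 2 to compound 4 (beyond the scatter), a modest change but the first that can be tied to a single group. The earlier compounds shown here differ from one another in more than one place, so their values could only be ranked. This pair shows that the number responds to this one aromatic carbon, ortho to a hydroxy group and para to a large group, while the chlorine and the rest of compound 2 stay the same; nothing shown here explains why the number rises.

The compounds shown carry no methoxy group, amine or fluorine at this position, so it remains open whether a hydroxy group is needed here or whether another group would give a similar step. Also open, going by these compounds, is what would happen to compound 4 if a hydroxy group or a carboxylic acid replaced its chlorine.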